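This account rests on a few compounds, and the source may have more. Where it says the series, first, only, none or still open, it means among the compounds named here.

In an ADME assay on microsomes from liver (Mus musculus) for metabolic stability, read by HPLC, with a stated time of 30 min (a lower number here means that less of the compound is left, a higher number that more of the compound is left), compound 1 (`Cc1ccc(NC(=O)C(=O)c2c[nH]c3cc(C)ccc23)cc1`) gives 90.2%. Compound 2 (`COc1ccc(NC(=O)C(=O)c2c[nH]c3cc(C#N)ccc23)cc1`) gives 87.5%, and these two numbers lie within the scatter of each other. Among the measured compounds shown here, they differ in more than one place, so no measured step isolates the change to compound 3 (`Cc1ccc(NC(=O)C(=O)c2c[nH]c3cc(C#N)ccc23)cc1`), which has methyl in place of methoxy on an aromatic carbon. Compound 1 also carries 4-methylphenyl and gives 90.2%, so no change beyond the scatter is expected. The expected step of a number 0.5 percentage points higher from compound 2 to compound 3 (within the scatter) is small. For compound 3 the estimated value is 88%, with an expected range from 78% to 96%.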

Compound 3, percent of the compound remaining: 88.2%
Estimate against measurement, compound 3: 0.2 percentage points below; the range from low to high includes it.
By their numbers in this assay, from the lowest: compounds 2, 3 and 1 (each within the scatter of the next).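

In this assay, among the compounds shown here, the first isolated reading of methyl in place of methoxy, para to a large group, gives a number 0.7 percentage points higher from compound 2 to compound 3 (within the scatter), so this assay does not separate these two groups at this place. The other single change, cyano in place of methyl on an aromatic carbon of the shared core, gives a number 2 percentage points lower from compound 1 to compound 3 (within the scatter), and so does not separate those two groups either. Nothing measured here bears on why these numbers stay together. Still open, going by these compounds, is whether an amine or a carboxylic acid at the place of the methyl would move the read-out beyond the scatter.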